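The compounds below may be only part of what the source reports. "The series", "measured", "known", "first", "only" and "open" are said of these compounds alone.

Measured compounds in a functional assay on MGC-803 cells (Homo sapiens) for inhibition, read by MTT assay, with a stated time of 48 h; on this read-out higher numbers stand for weaker inhibition and lower numbers for stronger inhibition:
compound 1, `CCC(=O)N(Cc1ccc(OC)c(O)c1)c1cc(OC)c(OC)c(OC)c1`: 50 nM
compound 2, `COc1ccc(CN(C(C)=O)c2cc(OC)c(OC)c(OC)c2)cc1O`: 79 nM

Compound 2 carries the larger of these two numbers, yet the step of a 1.6-fold higher number from compound 1 to compound 2 (0.20 log units; within the scatter) falls inside the usual scatter, so the two compounds cannot be told apart on this read-out. Compound 3, `COc1ccc(CN(C(=O)CN=[N+]=[N-])c2cc(OC)c(OC)c(OC)c2)cc1O`, differs from compound 2 by azido in place of hydrogen on a saturated chain carbon bound to a carbonyl carbon. Among the compounds with values here, the only measured step touches the same place: it exchanged methyl for hydrogen on a saturated chain carbon bound to a carbonyl carbon, and it produced a 1.6-fold higher number from compound 1 to compound 2 (0.20 log units; within the scatter), a change within the scatter. Within the data shown here, no measured step introduces an azido group, so the effect of this larger group is not known from the data. Because a 1.6-fold higher number from compound 1 to compound 2 (0.20 log units; within the scatter) shows this position tolerating a small change without a shift beyond the scatter, a modest step is expected for compound 3, a 1.4-fold higher number from compound 2 to compound 3 (0.14 log units; within the scatter), leaning toward a somewhat higher number. Compound 3 is thus estimated at 110 nM, with a range from 40 nM to 300 nM.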

Compound 3, half-maximal inhibitory concentration: 120 nM
Compound 3: the middle estimate sits 1.1-fold (0.04 log units) below what was measured, within the range that was stated.
By their numbers in this assay, from the lowest: compounds 1, 2 and 3 (each within the scatter of the next, the first and the last beyond it).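

In this assay, azido on a saturated chain carbon bound to a carbonyl carbon gives a 1.5-fold higher number from compound 2 to compound 3 (0.18 log units; within the scatter), so this place accepts a group of 3 heavy atoms in place of hydrogen with no shift that can be told from the scatter. Set against methyl at the same place, azido gives a 2.4-fold higher number from compound 1 to compound 3 (0.38 log units; beyond the scatter), the first step in this set beyond the scatter and a modest one, so the ends of the series can now be told apart, with inhibition weaker for the azidomethyl compound than for the compound with the longer, plain carbon chain. Nothing available here accounts for this gap.

The compounds shown leave open how an amine or a carboxylic acid on this same carbon would read out. They also leave open whether a chain longer than that of compound 1 would keep the number close to that of compound 1 or move it further.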